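The source may report more compounds than this note shows. Statements on the series, on what has been measured and on what is new or still open speak of the compounds shown alone.

Among the compounds with values here, compound 1 `Nc1cc(N)c2nc(-c3ccccc3)c(Oc3ccc(Cl)c(Cl)c3)nc2c1` is the only compound of the series with a number in a functional assay on SW-620 cells (Homo sapiens) for inhibition, read by sulforhodamine B assay, with a stated time of 48 h (on this read-out higher numbers stand for weaker inhibition of growth and lower numbers for stronger inhibition of growth), where compound 1 gives 30200 nM. Compound 2 `COc1ccc(CNc2nc3cc(N)cc(N)c3nc2-c2ccccc2)cc1OC` returns only a limit in this assay, < 100000 nM. This is the situation described by the limit of < 100000 nM in this assay, at which 1 of the 2 values shown sits. Compound 3 `Nc1cc(N)c2nc(-c3ccccc3)c(Sc3ccc(Cl)c(Cl)c3)nc2c1` has not yet been measured and carries (3,4-dichlorophenyl)sulfanyl in place of 3,4-dichlorophenoxy on an aromatic carbon. Within the data shown here, no measured pair shows what this change does, so the expected step in this assay, a 1.2-fold lower number from compound 1 to compound 3 (0.08 log units; within the scatter), is taken as none beyond the scatter. Compound 3 is therefore estimated at 25000 nM, expected to fall within 8000 nM to 80000 nM in this assay.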

Compound 3, concentration for total growth inhibition: 83200 nM
Compound 3: the middle estimate sits 3.3-fold (0.52 log units) below what was measured; measured number above the stated range.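

In this assay, the position next to the ring nitrogen and ortho to a phenyl group responds to the linking atom alone: (3,4-dichlorophenyl)sulfanyl in place of 3,4-dichlorophenoxy gives a 2.8-fold higher number from compound 1 to compound 3 (0.44 log units; beyond the scatter). The two groups match in their counts of heavy atoms, donors and acceptors, so the swap of oxygen for sulfur is the only difference, and the oxygen-linked compound 1 reads as the stronger inhibitor of growth. No measurement shown bears on the cause of this step.

Open, from the compounds shown here alone, is how a sulfonyl or methylene link in the same place would read in this assay. Also open, going by these compounds, is whether the step holds with the 3,4-dichloro pattern replaced by a different ring substituent, such as a methoxy group.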